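The source may report more compounds than this note shows. Statements on the series, on what has been measured and on what is new or still open speak of the compounds shown alone.

Working notes on the series. In a functional assay on K562 cells (Homo sapiens) for antiproliferative activity, read by MTT assay, with a stated time of 24 h (a higher number here means a weaker inhibitor, a lower number a stronger inhibitor), compound 3 (`COc1ccc(C(=O)/C=C/c2cccs2)c2c1C=CC(C)(C)O2`) gives > 10000 nM, which is a limit and not a number. Compound 1 (`COc1cccc(/C=C/C(=O)c2ccc(OC)c3c2OC(C)(C)C=C3)c1`) gives > 10000 nM, again only a limit. Compound 2 (`COc1ccc(/C=C/C(=O)c2ccc(OC)c3c2OC(C)(C)C=C3)c(F)c1`) gives > 10000 nM, also only a limit. The standing of compound 3 therefore rests on one shared ceiling: the limit of > 10000 nM in this assay, at which 3 of the 3 values shown sit.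

Compound 4 (`COc1ccc(C(=O)/C=C/c2ccccc2Cl)c2c1C=CC(C)(C)O2`) carries 2-chlorophenyl in place of thiophen-2-yl on a double-bonded chain carbon bound to a double-bonded chain carbon.

The measured exchanges at this same place are a step that the two limits leave unreadable from compound 1 to compound 2, a step that the two limits leave unreadable from compound 1 to compound 3 and a step that the two limits leave unreadable from compound 2 to compound 3. None of the three has a readable size, so they give no direction for the new exchange in this assay. All they show is that the 3-methoxyphenyl, 2-fluoro-4-methoxyphenyl and thiophen-2-yl compounds stay at the limit. On that basis compound 4 is expected to stay where compound 3 stands, with no step beyond the scatter, and a report of the limit alone is the likeliest outcome.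

The expected step is a step that the limit leaves unreadable from compound 3 to compound 4. The estimate for compound 4 is 14000 nM, with an expected range from 6000 nM to 35000 nM.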

Compound 4, half-maximal inhibitory concentration: > 10000 nM
Compound 4 was reported as a limit; the forecaster's own chance of this, stated with the estimate: 80%; the middle value is on the limit's open side.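

Compound 4 gives only a limit, so no step can be read between it and compound 1, compound 2 or compound 3, all of which share the same ceiling: the limit of > 10000 nM in this assay, at which 4 of the 4 values shown sit.

The compounds shown leave open how far any of these four lies from that ceiling, and which exchange at this place, if any, would bring a measurable value in this assay.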